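From Dichlorophenyl to Difluorophenyl on a Shared Core

The source may hold more compounds than are shown below. What is called first, only, known or untested is meant among the compounds shown, and "the series" means these compounds.

Going by the values given here, in a physicochemical assay for lipophilicity (on this read-out higher numbers stand for higher lipophilicity and lower numbers for lower lipophilicity), compound 2 `C[C@H]1CC[C@@H]2[C@@H](OC(=O)[C@]23CC(c2c(Cl)cccc2Cl)N(c2ccccc2)O3)[C@]2(C)C(=O)C=C[C@@]12O` gives 4.45, the higher of the two numbers measured so far, while compound 1 `Cc1ccc(C2C[C@@]3(ON2c2ccccc2)C(=O)O[C@@H]2[C@H]3CC[C@H](C)[C@]3(O)C=CC(=O)[C@@]23C)cc1` gives 3.64. Compound 3 `C[C@H]1CC[C@@H]2[C@@H](OC(=O)[C@]23CC(c2c(F)cccc2F)N(c2ccccc2)O3)[C@]2(C)C(=O)C=C[C@@]12O` has not yet been measured and differs from compound 2 in one place: 2,6-difluorophenyl in place of 2,6-dichlorophenyl on a saturated ring carbon. It carries 2,6-difluorophenyl in place of 2,6-dichlorophenyl on a saturated ring carbon, next to the ring nitrogen. Among the compounds with values here, only one measured step bears on this carbon, the one that introduced the 2,6-dichlorophenyl group: a number 0.81 log units higher from compound 1 to compound 2 (beyond the scatter). Within the data shown here, no measured compound yet carries the 2,6-difluorophenyl group, so this single modest step is the only guide to size. A downward step of similar size is expected in this assay, estimated as a number 0.75 log units lower from compound 2 to compound 3 (beyond the scatter). For compound 3 the expected value is 3.7, with an estimated range from 3.3 to 4.1.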

Compound 3, partition coefficient: 3.42
Compound 3: the middle estimate sits 0.28 log units above what was measured; the range from low to high includes it.
By their numbers in this assay, from the lowest: compounds 3 and 1 (each within the scatter of the next); then compound 2.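

On this saturated ring carbon, the exchange of 2,6-dichlorophenyl for 2,6-difluorophenyl gives in this assay a number 1.03 log units lower from compound 2 to compound 3 (beyond the scatter), a large step between two groups that match in heavy-atom count and in their aromatic ring. The other comparison shows a number 0.22 log units lower from compound 1 to compound 3 (within the scatter), so in this read-out the 2,6-difluorophenyl and 4-methylphenyl groups cannot be told apart, and among the three groups only 2,6-dichlorophenyl stands apart from the others. Nothing available explains why the two halogen-bearing groups differ so widely at this position.

On these data alone, it remains open what a phenyl ring with a single chlorine or a single fluorine would give on this carbon, and so whether both halogens are needed for a step of this size. Also open, as far as these compounds go, is where a 2,6-dimethylphenyl group, or a phenyl ring carrying an amine or a carboxylic acid, would fall on this read-out.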